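A few compounds are considered here, and "the series" means these few. Any claim that something is new, unique, unknown or untested is made for them only; others in the source may bear on it.

Compound 1 `COc1cc(Cl)c(-c2nc(SCC(=O)NC3CC3)nc3[nH]cc(C#N)c23)cc1O` gives 1160 nM in a functional assay on HCT-116 cells (Homo sapiens) for antiproliferative activity, read by sulforhodamine B assay, with a stated time of 4 days (on this read-out lower numbers stand for stronger inhibition of growth and higher numbers for weaker inhibition of growth), the higher of the two numbers shown. Compound 2 `CCOc1cc(-c2nc(SCC(=O)NC3CC3)nc3[nH]cc(C#N)c23)c(Cl)cc1OC` gives 20 nM in this assay, and a 58-fold lower number from compound 1 to compound 2 (1.76 log units; beyond the scatter) followed ethyl in place of hydrogen on an oxygen on an aromatic ring. Compound 3 `COc1cc(Cl)c(-c2nc(SCC(=O)N3CCC3)nc3[nH]cc(C#N)c23)cc1O` changes compound 1 elsewhere: azetidin-1-yl in place of cyclopropylamino on a carbonyl carbon. For the measured compounds named here, no measured step touches the carbonyl end of the chain, so that single large step offers no guide here, and a change within the scatter is expected. Compound 3 is therefore estimated at 1500 nM, with a range from 500 nM to 5000 nM, an expected 1.3-fold higher number from compound 1 to compound 3 (0.11 log units; within the scatter).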

Compound 3, concentration for 50% growth inhibition: 172 nM
Beside the measured number, compound 3's estimate is 8.7-fold (0.94 log units) above it; the measured number lies below the stated range.
By their numbers in this assay, from the lowest: compound 2; then compound 3; then compound 1.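

In this assay the carbonyl end of the chain proves to be a position that responds: azetidin-1-yl in place of cyclopropylamino on a carbonyl carbon gave a 6.7-fold lower number from compound 1 to compound 3 (0.83 log units; beyond the scatter) with the rest of the molecule unchanged. The two groups have the same heavy-atom count, while the amide hydrogen of cyclopropylamino is gone in azetidin-1-yl. No measurement bears on why the number fell. The compounds shown leave open how pyrrolidin-1-yl or dimethylamino would fare on this carbonyl carbon. They also leave open whether azetidin-1-yl and the ethyl on the aromatic oxygen would combine.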